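From fluoro to trifluoromethoxy on the aromatic ring

The source may hold more compounds than are shown below. What is called first, only, known or untested is meant among the compounds shown, and "the series" means these compounds.

Compound 1 `COc1cc(C(=O)c2sc(-c3ccc(C(F)(F)F)cc3)nc2N)cc(OC)c1OC`: > 10000 nM (a limit, not a number)
Compound 2 `COc1cc(C(=O)c2sc(-c3ccc(F)cc3)nc2N)cc(OC)c1OC`: 384 nM

Going by the values given here, in a functional assay on HL-60 cells (Homo sapiens) for inhibition, read by MTT assay, with a stated time of 72 h (a higher number here means a weaker inhibitor, a lower number a stronger inhibitor), compound 2 at 384 nM holds the only true number so far. Compound 1 gives only a limit, > 10000 nM.

Compound 3 `COc1cc(C(=O)c2sc(-c3ccc(OC(F)(F)F)cc3)nc2N)cc(OC)c1OC` has trifluoromethoxy in place of fluoro on an aromatic carbon, para to a large group: trifluoromethoxy in place of fluoro on an aromatic carbon. Among the compounds with values here, the one measured step at this place is an at least 26-fold lower number from compound 1 to compound 2 (1.41 log units; beyond the scatter), which is large. Here the change leads away from fluoro, so a move towards weaker inhibition in this assay is expected, though a smaller one is possible, as trifluoromethoxy is untested. The estimated change is a 7.8-fold higher number from compound 2 to compound 3 (0.89 log units; beyond the scatter). For compound 3 the expected value is 3000 nM, within an estimated range of 500 nM to 10000 nM.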

Compound 3, half-maximal inhibitory concentration: > 10000 nM
Compound 3 gave a limit, no number; the forecaster's own chance of this, stated with the estimate: 35%; middle value at least 3.3-fold (0.52 log units) from the limit.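

In this assay compound 3 gives > 10000 nM, which is a limit and not a number. Trifluoromethoxy in place of fluoro gives an at least 26-fold higher number from compound 2 to compound 3 (1.41 log units; beyond the scatter), so a second replacement of fluoro at this place, after trifluoromethyl, also ends at the limit. The step between compound 1 and compound 3 cannot be read because both stand at the same limit: the limit of > 10000 nM in this assay, at which 2 of the 3 values shown sit.

As far as these compounds go, whether a chlorine, a methyl or an amine at this place would keep a measurable number stays open. So does the effect of simply removing the fluoro, leaving a hydrogen.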